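Benzyl variants at the aromatic nitrogen of the shared core

This account rests on a few compounds, and the source may have more. Where it says the series, first, only, none or still open, it means among the compounds named here.

Three compounds of the series have numbers in a functional assay on RAW264.7 cells (Mus musculus) for inhibition, read by Griess assay, with stated times of 2 h and 24 h; on this read-out lower numbers stand for stronger inhibition and higher numbers for weaker inhibition. Compound 1 `COc1ccc([C@@H]2CC(=O)c3c(O)cc(OCc4cn(C5CCCC5)nn4)cc3O2)cc1O` gives 10500 nM in this assay. Compound 2 `CCCn1cc(COc2cc(O)c3c(c2)O[C@H](c2ccc(OC)c(O)c2)CC3=O)nn1` gives 9670 nM in this assay. Compound 3 `COc1ccc([C@@H]2CC(=O)c3c(O)cc(OCc4cn(Cc5ccccc5F)nn4)cc3O2)cc1O` gives 7320 nM in this assay. Compound 1 stands at the highest of the three numbers, but none of the gaps reaches beyond the scatter: a 1.1-fold lower number from compound 1 to compound 2 (0.04 log units; within the scatter), a 1.4-fold lower number from compound 1 to compound 3 (0.16 log units; within the scatter) and a 1.3-fold lower number from compound 2 to compound 3 (0.12 log units; within the scatter). The group on the aromatic nitrogen has so far made no difference that can be trusted.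

Compound 4 `COc1ccc([C@@H]2CC(=O)c3c(O)cc(OCc4cn(Cc5cccc(C(F)(F)F)c5)nn4)cc3O2)cc1O` is not yet measured in this assay. It differs from compound 1 in one place: 3-(trifluoromethyl)benzyl in place of cyclopentyl on an aromatic nitrogen. Going by the values given here, the step that bears most directly on it is the one to compound 3, where a benzyl group also replaced cyclopentyl and a 1.4-fold lower number from compound 1 to compound 3 (0.16 log units; within the scatter); the step to compound 2, a 1.1-fold lower number from compound 1 to compound 2 (0.04 log units; within the scatter), points the same way and is equally small. A step of no more than the scatter is therefore expected from compound 1 to compound 4, a 1.3-fold lower number from compound 1 to compound 4 (0.13 log units; within the scatter), leaning lower if anything. Compound 4 is estimated at 7800 nM in this assay, within 3900 nM to 15600 nM.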

Compound 4, half-maximal inhibitory concentration: 19900 nM
Beside the measured number, compound 4's estimate is 2.6-fold (0.41 log units) below it; the measured number lies above the stated range.
By their numbers in this assay, from the lowest: compounds 3, 2, 1 and 4 (each within the scatter of the next, the first and the last beyond it).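

In this assay, going by these compounds alone, the group on the aromatic nitrogen now gives steps beyond the scatter for the first time: a 2.7-fold higher number from compound 3 to compound 4 (0.43 log units; beyond the scatter) and a 2.1-fold higher number from compound 2 to compound 4 (0.31 log units; beyond the scatter) are both modest, but they show that the 2-fluorobenzyl and 3-(trifluoromethyl)benzyl groups are not interchangeable at this position. Compound 1 does not fit this separation, as a 1.9-fold higher number from compound 1 to compound 4 (0.28 log units; within the scatter) stays within the scatter, so cyclopentyl cannot be told apart from 3-(trifluoromethyl)benzyl here. Nothing available accounts for the gap between the two benzyl groups.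

The two benzyl groups differ in both the substituent and where it sits, and these compounds cannot separate those two changes. An unsubstituted benzyl, or a benzyl carrying an amine or a carboxylic acid, would show how far the ring substituent governs this position.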